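The compounds below may be only part of what the source reports. "The series", "measured", "known", "first", "only" and "open" are said of these compounds alone.

Measured in an assay on isolated protein for inhibition of prostaglandin G/H synthase 1 (Mus musculus), tested at 10 ug/mL; a lower number here means less inhibition, a higher number more inhibition at the concentration tested (going by the name of the read-out):
compound 1, `CS(=O)(=O)c1ccc(-c2oc3ccccc3c(=O)c2-c2cccc(Cl)c2)cc1`: < 5%
compound 2, `NS(=O)(=O)c1ccc(-c2oc3ccccc3c(=O)c2-c2ccccc2)cc1`: 61%
compound 3, `CS(=O)(=O)c1ccc(-c2oc3ccccc3c(=O)c2-c2ccc(Cl)cc2)cc1`: < 5%

The value of compound 1 is a limit of the assay, not a number. The value of compound 3 is likewise a limit, not a number. Compound 2 gives a number in this assay, 61%, and is the only one of the three to do so. Compound 3 therefore stands at the floor of what this assay reports, (the limit of < 5% in this assay, at which 2 of the 3 values shown sit). Within the data shown here, the one step between measured compounds, a step that the two limits leave unreadable from compound 1 to compound 3, is unreadable because both of its ends are limits.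

Compound 4, `CS(=O)(=O)c1ccc(-c2oc3ccccc3c(=O)c2-c2ccccc2)cc1`, differs from compound 3 in one place: hydrogen in place of chloro on an aromatic carbon. Among the measured compounds shown here, no measured step covers this change; the only measured step moves the chloro within the ring and cannot be read. Compound 2 carries the same unsubstituted ring as compound 4 but differs from it elsewhere, so its number is not a guide to the step followed here. With compound 3 sitting at the limit, the expectation for compound 4 is that the step of a number at least 5 percentage points higher from compound 3 to compound 4 (that floor lies within the scatter) stays within scatter of the floor. Compound 4 is estimated at 10%, with a range from 0% to 35%, and a fair chance that only a limit is reported.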

Compound 4, a percentage reported as inhibition, at one concentration (the size of the read-out at that concentration, not a potency): < 5%
Compound 4: a limit, no number; the forecaster's own chance of this, stated with the estimate: 55%; middle value at least 5 percentage points from the limit.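

In this assay compound 4 gives < 5%, which is a limit of the assay and not a number. The steps to compound 4 from compound 1 and from compound 3 have limits at both ends and cannot be read, so removing the chloro from the phenyl ring shows no measurable effect in either direction. Among these compounds, the new information lies at the sulfonyl sulfur, where compound 2 and compound 4 differ in that one place only, and methyl in place of amino gives a number at least 56 percentage points lower from compound 2 to compound 4 (beyond the scatter), the first readable step, though it rests on this single pair.

Whether a chloro on the phenyl ring changes inhibition at all stays open, as every compound with methyl on the sulfonyl sulfur sits at the same limit and no amino compound with a chlorophenyl ring is among those shown: the limit of < 5% in this assay, at which 3 of the 4 values shown sit. Also open is how much of the number for compound 2 would survive with another group on the sulfonyl sulfur, such as a dimethylamino or an ethyl group.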